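Methoxy for Methyl on the Fused Ring of Compound 3

The source may report more compounds than this note shows. Statements on the series, on what has been measured and on what is new or still open speak of the compounds shown alone.

Compound 1: `CCn1c(=O)/c(=C2\Sc3cc(F)ccc3N2C)s/c1=C\c1ccncc1Nc1ccccc1F` — 150 nM
Compound 2: `CCn1c(=O)/c(=C2\Sc3ccccc3N2C)s/c1=C\c1ccncc1Nc1cc(C)ccc1C` — 1800 nM
Compound 3: `CCn1c(=O)/c(=C2\Sc3ccc(C)cc3N2C)s/c1=C\c1ccncc1Nc1ccccc1Cl` — 350 nM

Of the compounds shown here, three built on one shared core have been tested in a functional assay on CWR22R cells (Homo sapiens) for inhibition; a lower number here means a stronger inhibitor, a higher number a weaker inhibitor. Compound 1 gives 150 nM, compound 2 gives 1800 nM, and compound 3 gives 350 nM. Among these three numbers compound 3 holds the second highest: its nearest neighbour is compound 1, whose number is lower by a margin that lies beyond the usual scatter, and the furthest is compound 2, whose number is higher by a wider margin, also beyond the scatter.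

Compound 4, `CCn1c(=O)/c(=C2\Sc3ccc(OC)cc3N2C)s/c1=C\c1ccncc1Nc1ccccc1Cl`, has not yet been measured. It differs from compound 3 in a single place: methoxy in place of methyl on an aromatic carbon. Among the compounds with values here, no pair among the measured compounds differs by this change alone, so nothing measured here tells what it does.

Given that silence, the expected step is a modest one, with no strong reason to expect a clear gain or a clear loss. Compound 4 is therefore expected to land near compound 3, with the estimated step from compound 3 to compound 4 in this assay being a 1.2-fold lower number from compound 3 to compound 4 (0.07 log units; within the scatter). The estimate for compound 4 in this assay is 300 nM, within a range from 120 nM to 800 nM.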

Compound 4, half-maximal inhibitory concentration: 500 nM
The estimate for compound 4 lay 1.7-fold (0.22 log units) below the measured number; low and high end bracket the measured number.
By their numbers in this assay, from the lowest: compound 1; then compounds 3 and 4 (each within the scatter of the next); then compound 2.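

In this assay putting methoxy in place of methyl on this aromatic carbon gives a 1.4-fold higher number from compound 3 to compound 4 (0.15 log units; within the scatter) and so the change, which adds one oxygen and one hydrogen-bond acceptor, has no effect here that can be separated from ordinary measurement scatter. Within the data shown here, this is the first direct reading of the change, since compounds 1, 2 and 3 differ from one another in more than one place and could not isolate it. Nothing available here bears on why the step is so small.

The two groups tested at this carbon say nothing yet about an amine, a hydroxyl, a carboxylic acid or a longer chain such as ethoxy, any of which might move the number well beyond the scatter. As far as these compounds go, it also remains open whether methoxy for methyl would give a similarly small step when the chlorine-bearing ring of compound 3 is replaced by the fluorine-bearing ring of compound 1 or the dimethyl-substituted ring of compound 2.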